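A few compounds are considered here, and "the series" means these few. Any claim that something is new, unique, unknown or untested is made for them only; others in the source may bear on it.

Working notes on the series. All three measured compounds share one core and differ only in the group on the saturated chain carbon bound to the nitrogen on the aromatic ring. In an assay on CHO cells for displacement of a labelled ligand from D(4) dopamine receptor (Homo sapiens), read by radioligand binding (on this read-out higher numbers stand for weaker inhibition and lower numbers for stronger inhibition), compound 1 `COc1ccccc1N1CCN(CCCCNC(=O)NN(Cc2ccccc2)c2ccc(F)cc2)CC1` gives 4.4 nM. Compound 2 `COc1ccccc1N1CCN(CCCNC(=O)NN(Cc2ccccc2F)c2ccc(F)cc2)CC1` gives 3.6 nM in this assay. Among the compounds with values here, compound 3 `COc1ccccc1N1CCN(CCCNC(=O)NN(Cc2ccc(F)cc2)c2ccc(F)cc2)CC1` gives 4.6 nM in this assay, and both compound 1 and compound 2 fall within the scatter of that number; the step of a 1.3-fold higher number from compound 2 to compound 3 (0.11 log units; within the scatter) is the only single-point change measured so far at this position, and it did not move the number beyond the scatter.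

Compound 4 `COc1ccccc1N1CCN(CCCNC(=O)NN(Cc2ccc(C#N)cc2)c2ccc(F)cc2)CC1` is not yet measured. It differs from compound 3 by cyano in place of fluoro on an aromatic carbon. Within the data shown here, no measured step swaps fluoro for cyano anywhere, so the only bearing on it comes from the step from compound 2 to compound 3, which shows that changing the substituent on this benzyl ring left the number within the scatter. The step of a 1.3-fold higher number from compound 3 to compound 4 (0.12 log units; within the scatter) is therefore expected to be small, with no direction called beyond the scatter. The estimate for compound 4 in this assay is 6 nM, with a range from 2.5 nM to 15 nM.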

Compound 4, inhibition constant: 15 nM
Compound 4: the middle estimate sits 2.5-fold (0.40 log units) below what was measured; the measured number falls inside the stated range.
By their numbers in this assay, from the lowest: compounds 2, 1 and 3 (each within the scatter of the next); then compound 4.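

In this assay, within the data shown here, this benzyl ring position turns out not to be indifferent to its substituent: cyano in place of fluoro, para to a large group, gives a 3.3-fold higher number from compound 3 to compound 4 (0.51 log units; beyond the scatter), the first single change to move the number beyond the scatter. The change from the 2-fluorobenzyl group gives a 4.2-fold higher number from compound 2 to compound 4 (0.62 log units; beyond the scatter), also modest and beyond the scatter, whereas a 1.3-fold higher number from compound 2 to compound 3 (0.11 log units; within the scatter) shows that moving between the two fluorinated benzyl groups leaves the number within the scatter, so among these three compounds only the cyano group sets one compound apart. Nothing available on these compounds accounts for the shift, and the numbers record its size and direction only.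

Still open, as far as these compounds go, is whether the higher number is particular to cyano or would also appear with other groups at this place, such as methoxy, trifluoromethyl, a carboxylic acid or an amine. Also open, from the compounds shown here alone, is whether the step from fluoro to cyano would keep its size with the longer chain of compound 1 in place of the shorter chain of compound 3.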